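A few compounds are considered here, and "the series" means these few. Any claim that something is new, unique, unknown or untested is made for them only; others in the source may bear on it.

Measured compounds:
- Compound 1, `Fc1ccc2nc(-c3cnccn3)n(C3CC3)c2c1`: 541 nM
- Compound 2, `CCc1ncncc1-c1nc2cc(F)c(F)cc2n1C1CC1`: 8 nM

Of the compounds shown here, two have been measured in an assay on cells for inhibition of cytochrome P450 11B2, mitochondrial (Homo sapiens), read by HPLC, with a stated time of 90 min; on this read-out higher numbers stand for weaker inhibition and lower numbers for stronger inhibition. Compound 1 gives 541 nM, and compound 2 gives 8 nM. Among the measured compounds shown here, of the two numbers, compound 2 stands lowest; its only neighbour is compound 1, whose number is higher by a margin that lies well beyond the scatter of repeated measurements. The two compounds differ in more than one place, so the gap between them cannot be tied to any single change.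

Compound 3, `CN(C)c1ncncc1-c1nc2cc(F)c(F)cc2n1C1CC1`, has not yet been measured in this assay. It is derived from compound 2 by a single replacement: dimethylamino in place of ethyl on an aromatic carbon. The rest of the molecule, including the shared core and the cyclopropyl on the ring nitrogen, is unchanged.

For the measured compounds named here, no measured pair shows what this exchange does. Since there is nothing in the measured set to lean on, the step from compound 2 to compound 3 is expected to be modest, likely toward a somewhat higher number, and not far outside the scatter. Compound 3 is therefore estimated at 20 nM, with a range from 6 nM to 70 nM, corresponding to an expected step of a 2.5-fold higher number from compound 2 to compound 3 (0.40 log units; beyond the scatter).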

Compound 3, half-maximal inhibitory concentration: 29 nM
The estimate for compound 3 lay 1.5-fold (0.16 log units) below the measured number; the range from low to high includes it.
By their numbers in this assay, from the lowest: compound 2; then compound 3; then compound 1.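

In this assay, among the compounds shown here, the exchange of ethyl for dimethylamino gives the first comparison in which only one place differs, and on the aromatic carbon next to the ring nitrogen it produces a 3.6-fold higher number from compound 2 to compound 3 (0.56 log units; beyond the scatter) and so counts as a modest loss that still lies beyond the scatter. Inhibition survives the exchange, since compound 3 still gives 29 nM with a group that brings one more heavy atom, a nitrogen and one hydrogen-bond acceptor, so this position accepts more than the ethyl of compound 2, although ethyl gives the lower number of the two. Nothing at hand explains why the number rises with this change, and no measurement bears on the cause.

The compounds shown cannot separate the contribution of the nitrogen from that of the extra heavy atom, and a methylamino group, a methoxy group or a longer chain such as propyl on the same carbon would speak to that. They also leave open whether the same step would appear on the core of compound 1, which carries a single fluorine and a different ring at this side.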